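This account rests on a few compounds, and the source may have more. Where it says the series, first, only, none or still open, it means among the compounds named here.

Of the compounds shown here, two have been measured in a functional assay on A549 cells (Homo sapiens) for antiproliferative activity, read by MTT assay, with a stated time of 48 h; on this read-out higher numbers stand for weaker inhibition and lower numbers for stronger inhibition. Compound 1 `C=CC(=O)Nc1cccc(Nc2nc(Nc3ccc(OCCn4ccnc4)cc3)ncc2Cl)c1` gives 8440 nM in this assay. Compound 2 `C=CC(=O)Nc1cccc(Nc2nc(Nc3ccc(Cn4ccnc4)cc3OC)ncc2Cl)c1` gives 14300 nM in this assay, and the two numbers lie within the usual scatter of each other, so compound 2 stands alongside compound 1 rather than apart from it. Compound 3 `C=CC(=O)Nc1cccc(Nc2nc(Nc3ccc(Cn4ccnc4)cc3)ncc2Cl)c1` has not yet been measured in this assay. It differs from compound 2 by one change, (hydrogen in place of methoxy on an aromatic carbon), that is, hydrogen in place of methoxy on an aromatic carbon. Going by the values given here, no measured pair isolates this change, so the expectation rests on the two numbers at hand. The step from compound 2 to compound 3 is expected to be small, a 1.4-fold lower number from compound 2 to compound 3 (0.16 log units; within the scatter), with no clear direction beyond the scatter. Compound 3 is accordingly estimated to give 10000 nM in this assay, within a range from 4000 nM to 25000 nM.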

Compound 3, half-maximal inhibitory concentration: 2730 nM
Estimate against measurement, compound 3: 3.7-fold (0.56 log units) above; the measured number lies below the stated range.
By their numbers in this assay, from the lowest: compound 3; then compounds 1 and 2 (each within the scatter of the next).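

In this assay, hydrogen in place of methoxy on the aromatic carbon ortho to a large group gives a 5.2-fold lower number from compound 2 to compound 3 (0.72 log units; beyond the scatter), so the number at this position does respond to that change. With no methoxy on the ring, (1H-imidazol-1-yl)methyl in place of 2-(1H-imidazol-1-yl)ethoxy gives a 3.1-fold lower number from compound 1 to compound 3 (0.49 log units; beyond the scatter), which shows that the group carrying the imidazole counts as well. Nothing at hand offers an explanation for either step.

The compounds shown leave open whether a fluorine or a hydroxyl group on that same carbon would give a number closer to that of compound 2 or that of compound 3. They also leave open how a 2-(1H-imidazol-1-yl)ethyl chain, which has no ether oxygen, would compare with the two groups seen so far.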